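This account rests on a few compounds, and the source may have more. Where it says the series, first, only, none or still open, it means among the compounds named here.

Series notes, antiproliferative set. Compound 1 `COc1ccc(/C=C/C(=O)c2ccc(OC)c3c2OC(C)(C)C=C3)c(F)c1` and compound 2 `COc1ccc(C(=O)/C=C/c2cccs2)c2c1C=CC(C)(C)O2` share the same core and differ only in the group on the chain. In a functional assay on HT-29 cells (Homo sapiens) for antiproliferative activity, read by MTT assay, with a stated time of 24 h (a higher number here means a weaker inhibitor, a lower number a stronger inhibitor), compound 1 gives > 10000 nM, which is a limit of the assay and not a number. In this assay compound 2 likewise gives > 10000 nM, again a limit rather than a number. The step that the two limits leave unreadable from compound 1 to compound 2 is therefore not readable, since the limit of > 10000 nM in this assay, at which 2 of the 2 values shown sit, holds both ends. On the numbers shown, compound 2 stands at the limit with no measured potency, and nothing separates it from compound 1.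

Compound 3 `COc1ccc(C(=O)/C=C/c2ccc(Cl)c(Cl)c2)c2c1C=CC(C)(C)O2` is the next member: 3,4-dichlorophenyl in place of thiophen-2-yl on a double-bonded chain carbon bound to a double-bonded chain carbon. Among the compounds with values here, no measured step bears on this change; the only step, from compound 1 to compound 2, cannot be sized because the limit of > 10000 nM in this assay, at which 2 of the 2 values shown sit, covers both values. With no readable step available, no direction is expected for this assay here, and the step that the limit leaves unreadable from compound 2 to compound 3 is expected to be none beyond the scatter. Compound 3 is expected at 15000 nM, with a range from 3000 nM to 60000 nM, most probably reported only as a limit.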

Compound 3, half-maximal inhibitory concentration: 7580 nM
Compound 3: middle estimate off by 2.0-fold (0.30 log units), on the high side, and the stated range covers the measured number.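

In this assay compound 3 gives 7580 nM, the only value of the three shown that is a number and not a limit, so 3,4-dichlorophenyl on a double-bonded chain carbon bound to a double-bonded chain carbon is the first group here to give a measured potency. Against thiophen-2-yl the change reads as an at least 1.3-fold lower number from compound 2 to compound 3 (0.12 log units; that floor lies within the scatter), and against 2-fluoro-4-methoxyphenyl it reads as an at least 1.3-fold lower number from compound 1 to compound 3 (0.12 log units; that floor lies within the scatter). Both are floors only, and their true sizes stay unknown because compound 1 and compound 2 both rest on a limit: the limit of > 10000 nM in this assay, at which 2 of the 3 values shown sit.

The step between compound 1 and compound 2 still cannot be read, and a six-membered aromatic ring of carbon alone does not give a numeric reading, since compound 1 carries such a ring and stands at a limit. From the compounds shown here alone, whether the two chlorine atoms together are needed stays open, as does the outcome with 4-chlorophenyl, 3-chlorophenyl or an unsubstituted phenyl at this place, or with a phenyl ring bearing an amine or a carboxylic acid.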